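A few compounds are considered here, and "the series" means these few. Any claim that something is new, unique, unknown or untested is made for them only; others in the source may bear on it.

Working notes on the series.

All compounds share one core bearing a hydrazone to a substituted phenyl. Compound 1 `O=C(CSc1nnc(-c2ccncc2)o1)N/N=C/c1ccc(F)cc1` carries fluoro, compound 2 `O=C(CSc1nnc(-c2ccncc2)o1)N/N=C/c1ccc(Cl)cc1` chloro, and compound 3 `Cc1ccc(/C=N/NC(=O)CSc2nnc(-c3ccncc3)o2)cc1` methyl on that aromatic carbon. In a functional assay on BGC-823 cells (Homo sapiens) for cytotoxicity, read by MTT assay, with a stated time of 48 h (a higher number here means a weaker inhibitor, a lower number a stronger inhibitor), compound 1 gives 17800 nM, compound 2 gives 20500 nM, and compound 3 gives 21800 nM. The three steps among them are small: a 1.2-fold higher number from compound 1 to compound 2 (0.06 log units; within the scatter), a 1.2-fold higher number from compound 1 to compound 3 (0.09 log units; within the scatter), and a 1.1-fold higher number from compound 2 to compound 3 (0.03 log units; within the scatter). Compound 3 therefore holds the largest of the three numbers, but its steps to compound 1 and compound 2 lie within the scatter, so the three compounds cannot be separated on these data.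

Compound 4 `O=C(CSc1nnc(-c2ccncc2)o1)N/N=C/c1ccccc1O` differs from compound 3 by 2-hydroxyphenyl in place of 4-methylphenyl on a carbon with a double bond to nitrogen. Within the data shown here, none of the measured steps bears directly on this change: each of them swaps fluoro, chloro or methyl for one another, and no compound with a hydroxyl on the phenyl has been measured. Among the measured compounds shown here, the only guidance is that all three swaps on this phenyl left the numbers in this assay within the scatter of one another. For compound 4 the expected step is a 1.1-fold lower number from compound 3 to compound 4 (0.04 log units; within the scatter), that is none beyond the scatter, with a wide range to reflect the absence of a comparable precedent. The estimate for compound 4 in this assay is 20000 nM, expected between 7000 nM and 55000 nM.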

Compound 4, half-maximal inhibitory concentration: 6160 nM
Compound 4: middle estimate off by 3.2-fold (0.51 log units), on the high side; measured number outside the range, below it.
By their numbers in this assay, from the lowest: compound 4; then compounds 1, 2 and 3 (each within the scatter of the next).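

In this assay, this position on the carbon with a double bond to nitrogen now shows a response beyond the scatter, which the swaps among fluoro, chloro and methyl did not show: the steps are a 3.5-fold lower number from compound 3 to compound 4 (0.55 log units; beyond the scatter) and a 3.3-fold lower number from compound 2 to compound 4 (0.52 log units; beyond the scatter) and also a 2.9-fold lower number from compound 1 to compound 4 (0.46 log units; beyond the scatter), all modest and all in the same direction. Compared with 4-methylphenyl, the entering 2-hydroxyphenyl carries 1 hydrogen-bond donor and 1 hydrogen-bond acceptor, but the identity of the group and its place on the phenyl change together, so the compounds shown cannot separate the contribution of the hydroxyl from that of its place. No measurement is available here that bears on why the number falls with this change.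

Still open, on these data alone, is whether the lower number depends on the hydroxyl itself, which a methoxy or an amine in its place on the phenyl would test. Also open, as far as these compounds go, is whether a compound with a hydroxyl elsewhere on the phenyl, or a second hydroxyl added to the 2-hydroxyphenyl, would keep, extend or lose this step.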